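The compounds below may be only part of what the source reports. "The series", "measured", "known", "first", "only" and "open" are said of these compounds alone.

In a functional assay on OVCAR-5 cells (Homo sapiens) for inhibition, read by CCK-8 assay, with a stated time of 72 h, tested at 10 uM (on this read-out higher numbers stand for more inhibition of growth at the one concentration tested and lower numbers for less inhibition of growth), compound 2 `CN(C)C(=O)c1cc2cnc(Nc3ccc(NC(=O)C4(C(=O)Nc5ccc(O)cc5)CC4)cc3)nc2n1C1CCCC1` gives 90.9% and compound 1 `CN(C)C(=O)c1cc2cnc(Nc3ccc(NC(=O)C4(C(=O)Nc5cccc(O)c5)CC4)cc3)nc2n1C1CCCC1` gives 86%, so the two stand level within the scatter. Compound 3 `CN(C)C(=O)c1cc2cnc(Nc3ccc(NC(=O)C4(C(=O)Nc5ccccc5)CC4)cc3)nc2n1C1CCCC1` differs from compound 2 by hydrogen in place of hydroxy on an aromatic carbon, with hydrogen in place of hydroxy on an aromatic carbon, para to a large group. Within the data shown here, the only measured step that bears on this is a number 4.9 percentage points higher from compound 1 to compound 2 (within the scatter), which exchanges 3-hydroxyphenyl for 4-hydroxyphenyl. Among the measured compounds shown here, no measured compound lacks the hydroxy, so the evidence is indirect. The expected change is a number 6.9 percentage points lower from compound 2 to compound 3 (within the scatter), a small downward step and none beyond the scatter. Compound 3 is estimated at 84%, with an expected range of 68% to 95%.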

Compound 3, percent growth inhibition at one concentration: 77.1%
Compound 3: middle estimate off by 6.9 percentage points, on the high side; the measured number falls inside the stated range.
By their numbers in this assay, from the lowest: compounds 3, 1 and 2 (each within the scatter of the next, the first and the last beyond it).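

The hydroxy on this phenyl ring now has a direct test in this assay: hydrogen in place of hydroxy on the aromatic carbon para to a large group gives a step beyond the scatter (a number 13.8 percentage points lower from compound 2 to compound 3 (beyond the scatter)). Measured against the 3-hydroxyphenyl analogue, the same exchange stays within the scatter (a number 8.9 percentage points lower from compound 1 to compound 3 (within the scatter)), so only the 4-hydroxyphenyl comparison shows a loss on removal. Nothing on hand explains this difference.

As far as these compounds go, whether the hydroxy itself is needed at this place remains open. An amine, a methoxy group or a carboxylic acid there could separate that question from simple substitution of the ring.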